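Methoxy for trifluoromethyl on the aromatic ring of compound 1

This account rests on a few compounds, and the source may have more. Where it says the series, first, only, none or still open, it means among the compounds named here.

Going by the values given here, the three measured members share one core and differ only in the group hung from the ring nitrogen, all tested in a functional assay on NCI-H23 cells (Homo sapiens) for antiproliferative activity; on this read-out lower numbers stand for stronger inhibition of growth and higher numbers for weaker inhibition of growth. Compound 1 `O=C(CCC1=CCN(Cc2ccc(C(F)(F)F)cc2)C1=O)NO` gives 6640 nM in this assay and stands highest of the three numbers, that is, weakest. Compound 2 `O=C(CCC1=CCN(Cc2cccc(C(F)(F)F)c2)C1=O)NO` gives 680 nM in this assay, and compound 3 `COc1cccc(CCCN2CC=C(CCC(=O)NO)C2=O)c1` gives 1170 nM. Both gaps to compound 1 lie beyond the scatter, but each of these two compounds differs from compound 1 in more than one place, so no single step can be read from them.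

Compound 4 `COc1ccc(CN2CC=C(CCC(=O)NO)C2=O)cc1` is not yet measured in this assay. It differs from compound 1 in one place: methoxy in place of trifluoromethyl on an aromatic carbon. Among the compounds with values here, no measured pair isolates this exchange, so the expectation rests only on the spread of the three numbers. Since compound 1 holds the weakest number, the step of a 2.2-fold lower number from compound 1 to compound 4 (0.35 log units; beyond the scatter) is expected to be a moderate gain, near the edge of the scatter. Compound 4 is estimated at 3000 nM in this assay, with a range from 800 nM to 12000 nM.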

Compound 4, concentration for 50% growth inhibition: 1640 nM
Compound 4: middle estimate off by 1.8-fold (0.26 log units), on the high side; low and high end bracket the measured number.
By their numbers in this assay, from the lowest: compounds 2, 3 and 4 (each within the scatter of the next, the first and the last beyond it); then compound 1.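

In this assay, going by these compounds alone, methoxy in place of trifluoromethyl on an aromatic carbon para to a large group gives a 4.0-fold lower number from compound 1 to compound 4 (0.61 log units; beyond the scatter), the first step that isolates a single change; it is modest but beyond the scatter. At this position, then, trifluoromethyl is not required for growth inhibition, and the exchange moves the number in the favourable direction. No measurement bearing on the origin of this step is available.

From the compounds shown here alone, whether a nitrile, a chlorine atom or an amine on the same aromatic carbon would give a step of similar direction and size remains open. Also open, going by these compounds, is whether methoxy in place of trifluoromethyl gives a comparable step elsewhere on the ring, since this single pair speaks only for this position.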